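Ethyl to pentyl on the cyclobutyl side chain

The source may hold more compounds than are shown below. What is called first, only, known or untested is meant among the compounds shown, and "the series" means these compounds.

Measured so far:
compound 1, `CCCC1([C@@H](O)C/C=C/C2[C@H](O)CC(=O)[C@@H]2CCc2ccc(C(=O)O)cc2)CCC1`: > 0.0001 nM
compound 2, `CCC1([C@@H](O)C/C=C/[C@H]2[C@H](O)CC(=O)[C@@H]2C/C=C\CCCC(=O)O)CCC1`: > 0.0001 nM

Both values come from an assay on CHO cells for binding affinity to prostaglandin E2 receptor EP3 subtype (Mus musculus); on this read-out higher numbers stand for weaker inhibition and lower numbers for stronger inhibition. For compound 1 the value reached there is a limit of the assay, not a number. For compound 2 the value is likewise a limit. For the measured compounds named here, compound 2 therefore stands at the assay limit, as does the only other value shown; the two structures differ in more than one place, so no structural step between them is counted. Evidence on the series is confined to the limit of > 0.0001 nM in this assay, at which 2 of the 2 values shown sit.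

Compound 3, `CCCCCC1([C@@H](O)C/C=C/[C@H]2[C@H](O)CC(=O)[C@@H]2C/C=C\CCCC(=O)O)CCC1`, awaits measurement in this assay. It differs from compound 2 by propyl in place of hydrogen on a saturated chain carbon, two bonds along the chain from a saturated ring carbon; read one bond further out, ethyl becomes pentyl.

Going by the values given here, no measured step exists, so no direction is drawn from the data. Compound 3 is expected to sit at the same limit, and the step of a number no higher from compound 2 to compound 3 (the limit leaves the size open) is expected to be none beyond the scatter. The estimate for compound 3 is 0.0001 nM, with a range from 0.00005 nM to 0.001 nM, most likely reported again as a limit rather than a number.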

Compound 3, inhibition constant: 830 nM
Compound 3: middle estimate off by 8300000-fold (6.92 log units), on the low side; measured number outside the range, above it.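

For the compounds shown here, the value of compound 2 is a limit of the assay, not a number, so no step from compound 2 to compound 3 can be read. The compounds shown leave open what ethyl to pentyl on this side chain does in this assay, in size or in direction.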